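Cytotoxicity notes: from methylsulfanyl to trifluoromethyl

A few compounds are considered here, and "the series" means these few. Any claim that something is new, unique, unknown or untested is made for them only; others in the source may bear on it.

Among the compounds with values here, in an ADME assay on HepG2 cells (Homo sapiens) for cytotoxicity, with a stated time of 72 h (on this read-out higher numbers stand for an effect only at larger amounts of compound and lower numbers for an effect already at smaller amounts), compound 1 (`CSc1ccc(NC(=O)Nc2cc(C)nc3ccccc23)cc1`) gives 16000 nM and stands as the only true number so far. Compound 2 (`Cc1cc(NC(=O)Nc2cccc([N+](=O)[O-])c2)c2ccccc2n1`) reads only as a limit (> 25000 nM) in this assay and gives no number. Compound 3 (`COc1ccc(NC(=O)Nc2cc(C)nc3ccccc23)cc1OC`) is likewise only a limit (> 25000 nM) in this assay and gives no number.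

The next compound to read is compound 4 (`Cc1cc(NC(=O)Nc2ccc(C(F)(F)F)cc2)c2ccccc2n1`). Compared with compound 1, it carries trifluoromethyl in place of methylsulfanyl on an aromatic carbon, para to a large group, and the rest of the structure is shared.

Within the data shown here, no two measured compounds differ in one place, so the series offers no measured size for a change of this kind. Among the measured compounds shown here, the only anchor is compound 1 at 16000 nM in this assay and this supports no firm direction. A change no larger than the usual scatter is therefore expected. The estimated step of a 1.1-fold lower number from compound 1 to compound 4 (0.06 log units; within the scatter) stays within that scatter. Compound 4 is expected at 14000 nM with an estimated range from 6000 nM to 25000 nM in this assay and could also read only as a limit.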

Compound 4, half-maximal effective concentration: 23000 nM
Beside the measured number, compound 4's estimate is 1.6-fold (0.22 log units) below it, within the range that was stated.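

The swap of trifluoromethyl in place of methylsulfanyl on an aromatic carbon, para to a large group, gives the series its first measured one-place step: in this assay it is a 1.4-fold higher number from compound 1 to compound 4 (0.16 log units; within the scatter), so the two compounds are not separated by this read-out. For this one pair, then, the number does not respond to the exchange of a group of 2 heavy atoms with 1 hydrogen-bond acceptor for a group of 4 heavy atoms with 0 hydrogen-bond acceptors, although a single pair sets no rule for the position. The step also has to be read with the top of the measurable range in mind, since the values shown there offer little room for any higher reading: the limit of > 25000 nM in this assay, at which 2 of the 4 values shown sit.

From the compounds shown here alone, whether an amine or a carboxylic acid at this same position would move the number beyond the scatter remains open. Going by these compounds, compound 2 and compound 3 stand only as limits, so steps involving them cannot be read, and the effect of changing the shared core also stays open.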